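A few compounds are considered here, and "the series" means these few. Any claim that something is new, unique, unknown or untested is made for them only; others in the source may bear on it.

In a functional assay on A549 cells (Homo sapiens) for inhibition, read by sulforhodamine B assay, with a stated time of 72 h (a higher number here means a weaker inhibitor, a lower number a stronger inhibitor), compound 1 `Nc1sc(-c2ccc(Cl)cc2)c(-c2ccc(Cl)cc2)c1C(=O)NC1CCC1` gives 12500 nM, compound 2 `Nc1sc(-c2ccc(Cl)cc2)c(-c2ccc(Cl)cc2)c1C(=O)Nc1ccccc1` gives 25000 nM and compound 3 `CC(C)CNC(=O)c1c(N)sc(-c2ccc(Cl)cc2)c1-c1ccc(Cl)cc1` gives 21000 nM. Compound 3 therefore stands within the scatter of both others: a 1.7-fold higher number from compound 1 to compound 3 (0.23 log units; within the scatter) and a 1.2-fold lower number from compound 2 to compound 3 (0.08 log units; within the scatter). Compound 4 `COc1ccc(CNC(=O)c2c(N)sc(-c3ccc(Cl)cc3)c2-c2ccc(Cl)cc2)cc1` carries 4-methoxyphenyl in place of isopropyl on a saturated chain carbon bound to an amide-type nitrogen. For the measured compounds named here, the only relevant steps are changes on that amide-type nitrogen, and a 2.0-fold higher number from compound 1 to compound 2 (0.30 log units; within the scatter) also lies within the scatter. Going by the values given here, no measured compound carries a 4-methoxybenzyl group, so the evidence is indirect. No change beyond the scatter is expected in this assay. The estimated step is a 1.2-fold lower number from compound 3 to compound 4 (0.09 log units; within the scatter). The expected value for compound 4 is 17000 nM, within an estimated range of 7500 nM to 35000 nM.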

Compound 4, half-maximal inhibitory concentration: 18200 nM
Estimate against measurement, compound 4: 1.1-fold (0.03 log units) below, within the range that was stated.
By their numbers in this assay, from the lowest: compounds 1, 4, 3 and 2 (each within the scatter of the next).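

In this assay, only compound 4 among these amides carries an aromatic ring and an oxygen on the saturated chain carbon, yet a 1.2-fold lower number from compound 3 to compound 4 (0.06 log units; within the scatter) stays within the scatter, as do a 1.4-fold lower number from compound 2 to compound 4 (0.14 log units; within the scatter) and a 1.5-fold higher number from compound 1 to compound 4 (0.16 log units; within the scatter). The cyclobutyl, phenyl, isobutyl and 4-methoxybenzyl groups on this amide-type nitrogen therefore give numbers that cannot be told apart. No measurement here accounts for this. On these data alone, whether an amine or a carboxylic acid in place of the 4-methoxyphenyl group would move the number beyond the scatter remains open.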